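Shortening the Link Once More: Compound 3

This account rests on a few compounds, and the source may have more. Where it says the series, first, only, none or still open, it means among the compounds named here.

Going by the values given here, compound 2 `COc1cc2nc(N3CCN(C(=O)CC4CCSS4)CC3)nc(N)c2cc1OC` gives the lowest of the two numbers so far in an assay on CHO cells with Alpha-1B adrenergic receptor (Homo sapiens) as the target (a higher number here means a weaker inhibitor, a lower number a stronger inhibitor), namely 0.309 nM. Its nearest neighbour, compound 1 `COc1cc2nc(N3CCN(C(=O)CCCCC4CCSS4)CC3)nc(N)c2cc1OC`, gives 1.26 nM in this assay. That single earlier step, a 4.1-fold lower number from compound 1 to compound 2 (0.61 log units; beyond the scatter), swapped a longer chain-plus-ring group for a shorter one. Compound 3 `COc1cc2nc(N3CCN(C(=O)C4CCSS4)CC3)nc(N)c2cc1OC` continues in the same sense: a group of 5 heavy atoms (3 carbon, 2 sulfur; one five-membered non-aromatic ring with 2 hetero atoms) in place of a group of 6 heavy atoms (4 carbon, 2 sulfur; one five-membered non-aromatic ring with 2 hetero atoms), on a carbonyl carbon, on a carbonyl carbon. Among the compounds with values here, only that one step bears on this change, and it pointed downward, so a further modest fall in this assay is expected, although it may simply level off. Compound 3 is estimated at 0.2 nM, within a range from 0.06 nM to 0.8 nM. This estimate means a step of a 1.5-fold lower number from compound 2 to compound 3 (0.19 log units; within the scatter).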

Compound 3, inhibition constant: 0.537 nM
Beside the measured number, compound 3's estimate is 2.7-fold (0.43 log units) below it; measured number inside the range.
By their numbers in this assay, from the lowest: compounds 2 and 3 (each within the scatter of the next); then compound 1.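

In this assay, removing the last stretch of chain gives a 1.7-fold higher number from compound 2 to compound 3 (0.24 log units; within the scatter) and so does not clearly extend the earlier gain: compounds 2 and 3 cannot be told apart at this position. Even so, the shortest group keeps an advantage over the longest, with a 2.3-fold lower number from compound 1 to compound 3 (0.37 log units; beyond the scatter) across the series. Nothing here accounts for this levelling off.

All three compounds keep the same five-membered ring with its two sulfur atoms. As far as these compounds go, whether an amine or a carboxylic acid on the carbonyl carbon in its place would give a similar number stays open.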